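The source may report more compounds than this note shows. Statements on the series, on what has been measured and on what is new or still open speak of the compounds shown alone.

Measured compounds:
Compound 1 `COc1ccc(Oc2ccccc2NC(C)=C2C(=O)CC(c3ccccc3)CC2=O)cc1` gives 120 nM in a functional assay on CCRF-CEM cells (Homo sapiens) for antiproliferative activity, read by cell counting, with a stated time of 96 h; on this read-out higher numbers stand for weaker inhibition and lower numbers for stronger inhibition.
Compound 2 `COc1cc(Oc2ccccc2NC(C)=C2C(=O)CC(c3ccccc3)CC2=O)ccc1N` gives 12 nM.
Compound 3 `CC(Nc1ccccc1Oc1cccc(F)c1)=C1C(=O)CC(c2ccccc2)CC1=O` gives 170 nM.

Compound 1 sits at the second highest of the three numbers in this assay. Its nearest neighbour is compound 3, reached through a 1.4-fold higher number from compound 1 to compound 3 (0.15 log units; within the scatter). Its furthest is compound 2, reached through a 10-fold lower number from compound 1 to compound 2 (1.00 log units; beyond the scatter), a step in which the 4-amino-3-methoxyphenyl replaces the 4-methoxyphenyl on the oxygen on the aromatic ring.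

Compound 4 `COc1cccc(Oc2ccccc2NC(C)=C2C(=O)CC(c3ccccc3)CC2=O)c1` is not yet measured. It differs from compound 1 in one place: 3-methoxyphenyl in place of 4-methoxyphenyl on an oxygen on an aromatic ring.

Going by the values given here, two measured steps bear on this. The step of a 1.4-fold higher number from compound 1 to compound 3 (0.15 log units; within the scatter) also exchanges the 4-methoxyphenyl for a group carrying its single substituent elsewhere, and it stays within the scatter. The step of a 10-fold lower number from compound 1 to compound 2 (1.00 log units; beyond the scatter) introduces a 3-methoxy group, but together with an amino group, so it cannot be read as the effect of the methoxy shift alone. Among the compounds with values here, the closest precedent therefore points to a small change, with the possibility of some improvement left open.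

Compound 4 is expected to show a 1.2-fold lower number from compound 1 to compound 4 (0.08 log units; within the scatter), and its estimated value is 100 nM, with a range from 40 nM to 250 nM.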

Compound 4, half-maximal inhibitory concentration: 41 nM
Estimate against measurement, compound 4: 2.4-fold (0.39 log units) above; the measured number falls inside the stated range.
By their numbers in this assay, from the lowest: compound 2; then compound 4; then compounds 1 and 3 (each within the scatter of the next).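

In this assay, the place of the methoxy group on the phenyl ring turns out to matter: with the same atoms joined differently, 3-methoxyphenyl in place of 4-methoxyphenyl gives a 2.9-fold lower number from compound 1 to compound 4 (0.47 log units; beyond the scatter), a change that the exchange for 3-fluorophenyl alone had not suggested for this position on the oxygen. The substituent itself also counts, since methoxy in place of fluoro on the aromatic carbon gives a 4.1-fold lower number from compound 3 to compound 4 (0.62 log units; beyond the scatter), so a group's location alone does not set the number. The new compound also splits the large earlier gain of compound 2 into parts, as hydrogen in place of amino gives a 3.4-fold higher number from compound 2 to compound 4 (0.53 log units; beyond the scatter), which shows that the amino group adds to what the methoxy shift already provides rather than accounting for all of it.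

The compounds shown leave open whether a larger ether such as ethoxy, or a hydroxy group, would serve at this place as well as methoxy does, and whether the amino group would help without the methoxy group beside the same phenyl ring's other substituents. Nothing available here explains why these differences arise.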